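The source may hold more compounds than are shown below. What is called first, only, known or untested is meant among the compounds shown, and "the series" means these compounds.

Compound 1 `CN(C)CC#Cc1cc2ncnc(Nc3ccc(OCc4cccc(F)c4)c(Cl)c3)c2s1`: > 32 uM
Compound 2 `CC(C)CC#Cc1cc2ncnc(Nc3ccc(OCc4cccc(F)c4)c(Cl)c3)c2s1`: > 32 uM
Compound 3 `CCOC(=O)CN(C)CC#Cc1cc2c(Nc3ccc(OCc4cccc(F)c4)c(Cl)c3)ncnc2s1`: > 28 uM

All three entries come from an ADME assay on HepG2 cells (Homo sapiens) for cytotoxicity (a higher number here means that more compound is tolerated, a lower number that less compound is tolerated), and each is a limit of the assay, not a number. For compound 3, > 28 uM is therefore a limit.

In compound 4 `Fc1cccc(COc2ccc(Nc3ncnc4sc(C#CCN5CCNCC5)cc34)cc2Cl)c1`, piperazin-1-yl stands in place of ((ethoxycarbonyl)methyl)(methyl)amino on a saturated chain carbon bound to a triple-bonded carbon (piperazin-1-yl in place of ((ethoxycarbonyl)methyl)(methyl)amino on a saturated chain carbon bound to a triple-bonded carbon).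

For the measured compounds named here, only one measured step changes this same place, a step that the two limits leave unreadable from compound 1 to compound 2, and it gives no size to carry over. No change beyond the usual scatter is expected, so the estimate is an at least 1.1-fold lower number from compound 3 to compound 4 (0.04 log units; that floor lies within the scatter).

For compound 4 the expected value is 25 uM, estimated to lie between 10 uM and 40 uM.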

Compound 4, half-maximal toxic concentration: 7.7 uM
Compound 4: middle estimate off by 3.2-fold (0.51 log units), on the high side; the whole stated range lies above it.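

Putting piperazin-1-yl in place of ((ethoxycarbonyl)methyl)(methyl)amino gives, in this assay, an at least 3.6-fold lower number from compound 3 to compound 4 (0.56 log units; beyond the scatter). For the compounds shown here, compound 4 is thus the first compound here with a real number rather than a limit, so this position can change how much compound the cells tolerate. The size is only a floor because compound 3 stands at a limit: the limit of > 28 uM in this assay, at which 1 of the 4 values shown sits.

Still open, on these data alone, is which part of piperazin-1-yl matters, its ring or its hydrogen-bond donor. A morpholin-4-yl or 4-methylpiperazin-1-yl group, each with the ring but without that donor, would separate the two.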